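The source may report more compounds than this note shows. Statements on the series, on what has been measured and on what is new or still open speak of the compounds shown alone.

Working notes on the series.

Compound 1 `O=C(Nc1cccc(Cl)c1)c1cccc(Br)c1` is the smaller amide; compound 2 `O=C(Nc1ccc(Sc2nc3ccccc3s2)c(Cl)c1)c1cccc(Br)c1` and compound 3 `O=C(Nc1ccc(Sc2nc3ccccc3s2)c(Cl)c1)c1cc(Br)ccc1O` carry a larger core, and how the core of compound 1 differs from the core of compound 2 is not broken down here. Compound 4 `O=C(Nc1cccc(Cl)c1)c1cc(Br)ccc1O` has not yet been measured.

In an assay for inhibition of HSP60/HSP10 (Homo sapiens), with a stated time of 60 min (on this read-out higher numbers stand for weaker inhibition and lower numbers for stronger inhibition), compound 1 gives > 100000 nM, which is a limit of the assay and not a number. In this assay compound 2 gives > 100000 nM, also a limit. In this assay compound 3 gives > 100000 nM, again a limit. All three values therefore sit at the limit of > 100000 nM in this assay, at which 3 of the 3 values shown sit.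

The change from compound 2 to compound 3 is hydroxy in place of hydrogen on an aromatic carbon. Its step that the two limits leave unreadable from compound 2 to compound 3 has no readable size because the limit of > 100000 nM in this assay, at which 3 of the 3 values shown sit, is where both of its ends sit. The change from compound 1 to compound 4 is hydroxy in place of hydrogen on an aromatic carbon, the same change at the same place.

Set beside that earlier step, the expected step that the limit leaves unreadable from compound 1 to compound 4 in this assay is also unreadable in practice, and the expectation rests on compound 1 already giving only a limit at the limit of > 100000 nM in this assay, at which 3 of the 3 values shown sit, and on compound 3 showing that this change did not bring its pair off that limit. Compound 4 is therefore expected at 150000 nM, within 50000 nM to 500000 nM, and most probably reported only as a limit again.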

Compound 4, half-maximal inhibitory concentration: > 100000 nM
Compound 4: no number, only a limit; the forecaster's own chance of this, stated with the estimate: 85%; the middle value is on the limit's open side.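

No size can be read for the step from compound 1 to compound 4 in this assay, because both ends are limits of the assay and not numbers: the limit of > 100000 nM in this assay, at which 4 of the 4 values shown sit.

The compounds shown leave open whether hydroxy in place of hydrogen on an aromatic carbon, or the difference between the core of compound 1 and the core of compound 2, changes inhibition at all.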